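The source may report more compounds than this note shows. Statements on the series, on what has been measured and on what is new or still open speak of the compounds shown alone.

Compound 1 `NC(=O)c1c(NC(=O)c2ccccc2I)sc2c1CCN(C(=S)Nc1ccccc1Cl)C2` is one of three close relatives tested in a functional assay on HeLa cells (Homo sapiens) for antiproliferative activity, with a stated time of 24 h; a lower number here means a stronger inhibitor, a higher number a weaker inhibitor. Its result there is a limit of the assay rather than a number: compound 1 gives > 50000 nM, and the limit of > 50000 nM in this assay, at which 1 of the 3 values shown sits, marks this. Compound 2 `NC(=O)c1c(NC(=O)c2ccccc2C(F)(F)F)sc2c1CCN(C(=S)Nc1ccccc1Cl)C2`, which carries trifluoromethyl in place of iodo on an aromatic carbon, gives 46900 nM in this assay. Compound 3 `Cc1ccccc1C(=O)Nc1sc2c(c1C(N)=O)CCN(C(=S)Nc1ccccc1Cl)C2`, with methyl at that carbon, gives 35300 nM in this assay. The measured steps are all small: an at least 1.0-fold lower number from compound 1 to compound 2 (0.02 log units; that floor lies within the scatter), an at least 1.4-fold lower number from compound 1 to compound 3 (0.15 log units; that floor lies within the scatter) and a 1.3-fold lower number from compound 2 to compound 3 (0.12 log units; within the scatter).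

Compound 4 `COc1ccccc1NC(=S)N1CCc2c(sc(NC(=O)c3ccccc3I)c2C(N)=O)C1` is not yet measured. It differs from compound 1 at a different place, on the other aromatic ring of the shared core: methoxy in place of chloro on an aromatic carbon. For the measured compounds named here, none of the measured steps touches this position, so they bear on it only as a backdrop of weak activity across all three compounds. With no evidence that this change moves the number, compound 4 is expected to stay near compound 1, with an estimated step that the limit leaves unreadable from compound 1 to compound 4 in this assay. The estimate for compound 4 is 60000 nM, in the range 25000 nM to 150000 nM.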

Compound 4, half-maximal inhibitory concentration: > 50000 nM
Compound 4: only a limit was reported (the forecaster's own chance of this, stated with the estimate: 60%); the middle value is on the limit's open side.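

Compound 1 and compound 4 both end at a limit in this assay rather than at a number, so no step can be read between them: the limit of > 50000 nM in this assay, at which 2 of the 4 values shown sit.

The compounds shown leave open whether methoxy in place of chloro on an aromatic carbon changes the activity at all.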